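Ester shortening in dihydropyridine calcium channel inhibitors

A few compounds are considered here, and "the series" means these few. Any claim that something is new, unique, unknown or untested is made for them only; others in the source may bear on it.

Measured so far: compound 1 `COC(=O)C1=C(C)NC(C)=C(C(=O)OC)C1c1ccc(-c2cc(=O)cc(C)o2)cc1` with 17800 nM; compound 2 `CCOC(=O)C1=C(C)NC(C)=C(C(=O)OCC)C1c1cc(=O)cc(-c2ccccc2)o1` with 3240 nM; compound 3 `CCOC(=O)C1=C(C)NC(C)=C(C(=O)OC)C1c1ccc(-c2cc(=O)cc(C)o2)cc1` with 86100 nM, all in an assay on isolated protein (strain albino) for inhibition of Voltage-dependent L-type calcium channel subunit alpha-1C (Cavia porcellus); a higher number here means a weaker inhibitor, a lower number a stronger inhibitor.

Compound 2 gives the lowest number of the three, and compound 3 the highest. The change hydrogen in place of methyl on a saturated chain carbon bound to an oxygen next to a carbonyl group produced a 4.8-fold lower number from compound 3 to compound 1 (0.68 log units; beyond the scatter). The unmeasured compound 4 `CCOC(=O)C1=C(C)NC(C)=C(C(=O)OC)C1c1cc(=O)cc(-c2ccccc2)o1` arises from compound 2 by hydrogen in place of methyl on a saturated chain carbon bound to an oxygen next to a carbonyl group, the same kind of change on a different core; the difference between the core of compound 2 and the core of compound 3 is not broken down here. The core of compound 2 is not the core of compound 3, so the expected step is kept smaller than the measured one. Because the same kind of change gave a 4.8-fold lower number from compound 3 to compound 1 (0.68 log units; beyond the scatter), a step of similar direction is expected here: a 2.5-fold lower number from compound 2 to compound 4 (0.40 log units; beyond the scatter). Compound 4 is thus estimated at 1300 nM, likely between 350 nM and 4500 nM.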

Compound 4, half-maximal inhibitory concentration: 2030 nM
Beside the measured number, compound 4's estimate is 1.6-fold (0.19 log units) below it; the range from low to high includes it.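

In this assay the exchange of ethoxycarbonyl for methoxycarbonyl gives a 1.6-fold lower number from compound 2 to compound 4 (0.20 log units; within the scatter) and so has no clear effect on this core. The size of the step did not carry over from the other core, where the same change was clear: the same change on two cores in this assay, a 4.8-fold lower number (0.68 log units; beyond the scatter) from compound 3 to compound 1 and a 1.6-fold lower number (0.20 log units; within the scatter) from compound 2 to compound 4, 3.0-fold (0.48 log units) apart, beyond the scatter of two such steps. This shows that the step differs between these two cores, but it does not show which part of the cores accounts for the difference, and two pairs set no rule for any further core.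

The compounds shown leave open how a longer chain, such as a propyl or isopropyl ester, would behave on either core. They also leave open what an amide or a carboxylic acid in place of the ester would do.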